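The source may hold more compounds than are shown below. What is called first, only, known or untested is meant among the compounds shown, and "the series" means these compounds.

For the measured compounds named here, in a functional assay on SGC-7901 cells (Homo sapiens) for antiproliferative activity, read by MTT assay, with a stated time of 24 h (a higher number here means a weaker inhibitor, a lower number a stronger inhibitor), compound 2 `Cc1ccccc1-n1cc(-c2cccc(NS(=O)(=O)c3c[nH]c(=O)[nH]c3=O)c2)nn1` gives 9230 nM, the only full number in this small set. Compound 1 `O=c1[nH]cc(S(=O)(=O)Nc2ccccc2-c2cn(-c3cccc(F)c3)nn2)c(=O)[nH]1` reaches only the limit of the assay at > 20000 nM, as recorded in the limit of > 20000 nM in this assay, at which 1 of the 2 values shown sits. Compound 3 `O=c1[nH]cc(S(=O)(=O)Nc2cccc(-c3cn(-c4cccc(Cl)c4)nn3)c2)c(=O)[nH]1` has not yet been measured. It differs from compound 2 in one place: 3-chlorophenyl in place of 2-methylphenyl on an aromatic nitrogen. Going by the values given here, no step between two measured compounds exists here, so nothing measured tells how large this change should be. The step from compound 2 to compound 3 is expected to be a 1.2-fold lower number from compound 2 to compound 3 (0.09 log units; within the scatter), a shift no larger than the scatter. Compound 3 is therefore estimated at 7500 nM, in a range from 2500 nM to 25000 nM.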

Compound 3, half-maximal inhibitory concentration: 3950 nM
Estimate against measurement, compound 3: 1.9-fold (0.28 log units) above; the range from low to high includes it.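

For the compounds shown here, on an aromatic nitrogen of the five-membered ring, the swap gives the only step that can be read in this set: in this assay, there is a 2.3-fold lower number from compound 2 to compound 3 (0.37 log units; beyond the scatter). This position therefore responds to the choice of aryl group, modestly, even though both groups are single six-membered carbon rings with the same heavy-atom count. Nothing measured here explains the size of this step.

On these data alone, the chlorine and the methyl differ in both identity and place, so the contribution of each stays open. So does the effect of an amine on this ring, or of a longer alkyl chain replacing the ring at this nitrogen.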